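Adding a 2-methoxybenzyl group to compound 3

A few compounds are considered here, and "the series" means these few. Any claim that something is new, unique, unknown or untested is made for them only; others in the source may bear on it.

Measured so far in a functional assay on the whole organism with Rattus norvegicus as the target; on this read-out higher numbers stand for an effect only at larger amounts of compound and lower numbers for an effect already at smaller amounts:
compound 1 `CCN(CCNC(=O)c1cc(Cl)c(N)cc1OC)Cc1ccccc1` gives 0.31 mg/kg
compound 2 `CCN(CCNC(=O)c1cc(Cl)c(N)cc1OC)Cc1ccccn1` gives 30 mg/kg
compound 3 `CCNCCNC(=O)c1cc(Cl)c(N)cc1OC` gives > 30 mg/kg as a limit

Compound 3 stands at the limit of > 30 mg/kg in this assay, at which 1 of the 3 values shown sits, and so has no number of its own. Compound 4 `CCN(CCNC(=O)c1cc(Cl)c(N)cc1OC)Cc1ccccc1OC` has 2-methoxybenzyl in place of hydrogen on an amine nitrogen, a change counted as 2-methoxybenzyl in place of hydrogen on an amine nitrogen and not yet measured. The nearest measured change is an at least 96-fold higher number from compound 1 to compound 3 (1.98 log units; beyond the scatter) where hydrogen replaces benzyl, a large step running the opposite way. The step of a 97-fold higher number from compound 1 to compound 2 (1.99 log units; beyond the scatter) is also large, so a benzyl-like group alone does not assure a low number. The step of a number no lower from compound 2 to compound 3 (the limit leaves the size open) leaves its size open. A large fall in this assay is therefore expected, estimated as an at least 30-fold lower number from compound 3 to compound 4 (1.47 log units; beyond the scatter) in this account. Compound 4 is estimated at 1 mg/kg with 0.2 mg/kg to 10 mg/kg as the expected range.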

Compound 4, dose for half-maximal effect: 10 mg/kg
Compound 4: the middle estimate sits 10-fold (1.00 log units) below what was measured; low and high end bracket the measured number.
By their numbers in this assay, from the lowest: compound 1; then compound 4; then compound 2.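

In this assay, a single methoxy in place of hydrogen on an aromatic carbon of the benzyl group carries a large cost (a 32-fold higher number from compound 1 to compound 4 (1.51 log units; beyond the scatter)), so the ring at this position tolerates substitution poorly. The 2-methoxyphenyl group still gives only a modest gain over pyridin-2-yl (a 3.0-fold lower number from compound 2 to compound 4 (0.48 log units; beyond the scatter)). Adding 2-methoxybenzyl to the amine nitrogen lowers the number (an at least 3.0-fold lower number from compound 3 to compound 4 (0.47 log units; beyond the scatter)), but this is only a minimum, as compound 3 has a limit and no number of its own: the limit of > 30 mg/kg in this assay, at which 1 of the 4 values shown sits.

Going by these compounds, whether a fluorine on the same ring would cost as much as methoxy remains open. So does the effect of a phenethyl group on the amine nitrogen.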